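Dibenzyl Ester Side Chain Replacing Isopropyl in Compound 1

This account rests on a few compounds, and the source may have more. Where it says the series, first, only, none or still open, it means among the compounds named here.

Measured compounds:
Compound 1 `CC(C)[C@H](NC(=O)CN(c1nc(Cl)nc2[nH]cnc12)C1CC1)C(=O)OCc1ccccc1` gives 27.3%
Compound 2 `O=C(OCc1ccccc1)[C@@H]1CCCN1C(=O)CN(c1nc(Cl)nc2[nH]cnc12)C1CC1` gives 38.4%
Compound 3 `O=C(CN(c1nc(Cl)nc2[nH]cnc12)C1CC1)N[C@@H](CO)C(=O)O` gives 39%

All three were tested in a functional assay on the whole organism (Tail, strain ICR) with Mus musculus as the target, in the tail flick test, with a stated time of 120 min, at a dose of 25 umol/kg by the oral route; on this read-out higher numbers stand for a stronger effect at the one dose given and lower numbers for a weaker effect. Compound 1 stands lowest of the three numbers; compound 2 and compound 3 both lie above it by more than the scatter, while compound 2 and compound 3 sit within the scatter of each other. Compound 4 `O=C(CN(c1nc(Cl)nc2[nH]cnc12)C1CC1)N[C@@H](CCC(=O)OCc1ccccc1)C(=O)OCc1ccccc1` has not yet been measured. It differs from compound 1 as follows: 2-(benzyloxycarbonyl)ethyl in place of isopropyl on a saturated chain carbon bound to an amide-type nitrogen and a carbonyl carbon. Going by the values given here, no step between measured compounds shows what this kind of change does. The step is therefore expected to be small, and the direction is uncertain, because compound 2 with a benzyl ester reaches only 38.4%. Compound 4 is estimated at 33%, within 15% to 52%, an expected step of a number 5.7 percentage points higher from compound 1 to compound 4 (within the scatter).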

Compound 4, a percentage reported as activity, at one dose (the size of the read-out at that dose, not a potency): 45.9%
Beside the measured number, compound 4's estimate is 12.9 percentage points below it, and the stated range covers the measured number.
By their numbers in this assay, from the lowest: compound 1; then compounds 2, 3 and 4 (each within the scatter of the next).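

In this assay, the place on a saturated chain carbon bound to an amide-type nitrogen and a carbonyl carbon accepts 2-(benzyloxycarbonyl)ethyl instead of isopropyl, and the read-out rises (a number 18.6 percentage points higher from compound 1 to compound 4 (beyond the scatter)). Going by these compounds alone, this is the first step in the set to change this place alone, and it shows that the added aromatic ring and ester are tolerated here. Nothing measured explains the rise.

From the compounds shown here alone, whether the ester, the aromatic ring or the chain length matters remains open. A plain butyl chain, or the same ethyl chain ending in a carboxylic acid, would help separate these.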